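The source may hold more compounds than are shown below. What is called first, only, known or untested is meant among the compounds shown, and "the series" means these compounds.

Measured in a functional assay on BT-483 cells (Homo sapiens) for cytotoxicity, read by MTT assay, with a stated time of 24 h; on this read-out higher numbers stand for weaker inhibition and lower numbers for stronger inhibition:
- Compound 1 `CCNc1cc(-c2ccc(NC(=O)Nc3ccccc3Cl)cc2C)ccn1`: > 30000 nM (a limit)
- Compound 2 `CCNc1cc(-c2ccc(NC(=O)Nc3ccc(OC)cc3)cc2OC)ccn1`: > 30000 nM (a limit)
- Compound 3 `CCNc1cc(-c2ccc(NC(=O)Nc3ccc(C(F)(F)F)cc3)cc2OC)ccn1`: 25600 nM

For the measured compounds named here, compound 3 gives 25600 nM, the only actual number in this small set. The other two results are limits, and the set as a whole is framed by the limit of > 30000 nM in this assay, at which 2 of the 3 values shown sit.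

The compound still to be measured is compound 4 `CCNc1cc(-c2ccc(NC(=O)Nc3ccccc3Cl)cc2OC)ccn1`. Its difference from compound 3 is 2-chlorophenyl in place of 4-(trifluoromethyl)phenyl on an amide-type nitrogen.

Going by the values given here, only one measured step involves the same part of the molecule, a swap of methoxy for trifluoromethyl on an aromatic carbon: an at least 1.1-fold lower number from compound 2 to compound 3 (0.06 log units; that floor lies within the scatter). It offers no sign of a large effect from changing this group. Compound 1 also carries 2-chlorophenyl on an amide-type nitrogen. In this assay compound 1 gives > 30000 nM, which is a limit of the assay.

On this basis, no step beyond the scatter is expected in either direction, and a result reported only as a limit would be no surprise. The estimated step is a 1.2-fold higher number from compound 3 to compound 4 (0.07 log units; within the scatter). For compound 4 the expected value is 30000 nM, with an estimated range from 16000 nM to 60000 nM.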

Compound 4, half-maximal inhibitory concentration: > 30000 nM
Compound 4 ended at the assay's limit; the forecaster's own chance of this, stated with the estimate: 65%; the middle value lies on the limit itself.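

In this assay, on these data alone, 2-chlorophenyl in place of 4-(trifluoromethyl)phenyl on an amide-type nitrogen gives an at least 1.1-fold higher number from compound 3 to compound 4 (0.06 log units; that floor lies within the scatter); only this floor can be read, and the true size of the step remains unknown. For the compounds shown here, the result adds a second group on this nitrogen, alongside the 4-methoxyphenyl of compound 2, that gives no actual number, while compound 3 remains the only compound with one, and the data support no order among the three. The steps from compound 2 and from compound 1 to compound 4 cannot be read, with limits at both ends of each, and the set as a whole now presses against a single boundary: the limit of > 30000 nM in this assay, at which 3 of the 4 values shown sit.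

What the compounds shown leave open is whether any group on this amide-type nitrogen can bring the number clearly beyond the scatter from the limit. An aromatic ring carrying an amine or a carboxylic acid in this place would test that, and a measurable value for such a compound would give a step of readable size.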